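The compounds below may be only part of what the source reports. "The series", "measured", "known", "first", "only" and "open" are said of these compounds alone.

Compound 1 `CS(=O)(=O)c1ccc(C(=O)Nc2ccc(Cl)c(-c3nnc4c(Cl)cccn34)c2)c(Cl)c1` is the parent of the exchange; in a functional assay on MDA-MB-231 cells (Homo sapiens) for antiproliferative activity, read by MTT assay, with stated times of 72 h and 4 h (on this read-out higher numbers stand for weaker inhibition and lower numbers for stronger inhibition), compound 1 gives 37200 nM. Compound 2 `Cc1nc(C(=O)Nc2ccc(Cl)c(-c3nnc4c(Cl)cccn34)c2)cs1` returns only a limit of the assay in this assay, > 100000 nM. Compound 3 `O=C(Nc1ccc(Cl)c(-c2nnc3c(Cl)cccn23)c1)c1c(F)cccc1Cl` likewise returns a limit in this assay, > 100000 nM. Among the measured compounds shown here, the one comparable step, a step that the two limits leave unreadable from compound 2 to compound 3, therefore cannot be sized. Compound 1 stands as the only number shown in this set; the two further values are limits, and the limit of > 100000 nM in this assay, at which 2 of the 3 values shown sit, is where both of them sit. Compound 4 `O=C(Nc1ccc(Cl)c(-c2nnc3c(Cl)cccn23)c1)c1ccc(Cl)cc1Cl` differs from compound 1 by chloro in place of methylsulfonyl on an aromatic carbon. No measured step touches this position of the core, and the single measured step between compounds 2 and 3 is unreadable, so nothing in the shown data sizes this exchange either way. For the measured compounds named here, the only footholds are that compound 1 itself is weak at 37200 nM and that the other two analogues give no number at all. Compound 2 and compound 3 each return a limit of the assay. For compound 4 a step of a 1.2-fold higher number from compound 1 to compound 4 (0.08 log units; within the scatter) is expected, small or none beyond the scatter, with a fair chance that only a limit is returned. The estimate for compound 4 is 45000 nM, with a range from 12000 nM to 150000 nM.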

Compound 4, half-maximal inhibitory concentration: > 100000 nM
Compound 4: a limit, no number; the forecaster's own chance of this, stated with the estimate: 40%; at least 2.2-fold (0.34 log units) between middle value and limit.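

In this assay, among the compounds shown here, the exchange of methylsulfonyl for chloro gives the only readable step in the set, an at least 2.6-fold higher number from compound 1 to compound 4 (0.42 log units; beyond the scatter), and it is readable in one direction only, since its far end is a limit and not a number. The change on an aromatic carbon, meta to a chloro group and para to a large group, therefore moves the read-out beyond the scatter, and the loss on leaving methylsulfonyl has a lower bound but no size. The steps from compound 2 and from compound 3 to compound 4 cannot be read, and compound 1 remains the only compound with a number, the others sharing one limit: the limit of > 100000 nM in this assay, at which 3 of the 4 values shown sit.

Open, from the compounds shown here alone, is whether the number of compound 1, 37200 nM, depends on methylsulfonyl itself or would also appear with another group at this place, such as a primary sulfonamide, a carboxylic acid or a nitrile. Equally open, going by these compounds, is whether an amine or a longer chain there would give a number clearly lower than that of compound 1.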